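The compounds below may be only part of what the source reports. "The series", "measured", "known", "first", "only" and "open" are said of these compounds alone.

Compound 1 `Nc1cc(N)c2nc(-c3ccccc3)c(Oc3ccc(Cl)c(Cl)c3)nc2c1` gives 69200 nM. Compound 3 `COc1cc(CNc2nc3cc(N)cc(N)c3nc2-c2ccccc2)cc(OC)c1OC` gives 37200 nM. Compound 2 `CCOC(=O)[C@H](CCC(=O)O)NC(=O)c1ccc(CNc2nc3cc(N)cc(N)c3nc2-c2ccccc2)cc1` is reported only as a limit, < 100000 nM.

In a functional assay on SF-295 cells (Homo sapiens) for inhibition, read by sulforhodamine B assay, with a stated time of 48 h (on this read-out higher numbers stand for lower toxicity in this test and lower numbers for higher toxicity in this test), compound 1 holds the highest of the two numbers; the value of compound 3 sits a little lower, but within the usual scatter, so the two cannot be told apart. The value of compound 2 is a limit of the assay and not a number (the limit of < 100000 nM in this assay, at which 1 of the 3 values shown sits). Compound 4 `Nc1cc(N)c2nc(-c3ccccc3)c(Sc3ccc(F)cc3)nc2c1` has not yet been tested; it differs from compound 1 by (4-fluorophenyl)sulfanyl in place of 3,4-dichlorophenoxy on an aromatic carbon. Within the data shown here, no measured pair here differs in only one place, so there is nothing to anchor the size of this change. For compound 4 the step of a 1.2-fold lower number from compound 1 to compound 4 (0.06 log units; within the scatter) is expected to stay within the scatter. The estimate for compound 4 is 60000 nM, expected between 20000 nM and 150000 nM.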

Compound 4, concentration lethal to 50% of the cells: 64600 nM
The estimate for compound 4 lay 1.1-fold (0.03 log units) below the measured number, and the stated range covers the measured number.
By their numbers in this assay, from the lowest: compounds 3, 4 and 1 (each within the scatter of the next).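

In this assay, among these compounds, (4-fluorophenyl)sulfanyl in place of 3,4-dichlorophenoxy on this aromatic carbon gives a 1.1-fold lower number from compound 1 to compound 4 (0.03 log units; within the scatter), the first step here between compounds differing in one place. So at this position, exchanging the oxygen-linked dichlorinated ring for a sulfur-linked fluorinated ring leaves the two compounds indistinguishable in this test. Nothing measured here explains this result.

From the compounds shown here alone, the linking atom and the ring halogens differ together, so their separate contributions remain open. Also open, going by these compounds, is how a small group such as an amine or a carboxylic acid would read at this position.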